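Amide in Place of Acid: Expecting Compound 3

This account rests on a few compounds, and the source may have more. Where it says the series, first, only, none or still open, it means among the compounds named here.

Compound 1, `CCCCCCCCN(C)C(=O)Cn1cc(Cc2cnc(OC)nc2)c(=O)nc1SCc1ccc(F)cc1`: 39%
Compound 2, `CCCCCCCCN(C)C(=O)Cn1cc(Cc2cnc(=O)n(CC(=O)O)c2)c(=O)nc1SCc1ccc(F)cc1`: 56%

For the measured compounds named here, in a functional assay on a cell-free system (plasma) for inhibition of platelet-activating factor acetylhydrolase (Homo sapiens), tested at 100 nM (a lower number here means less inhibition, a higher number more inhibition at the concentration tested (going by the name of the read-out)), compound 2 stands highest of the two numbers measured so far; its nearest neighbour is compound 1, and the step of a number 17 percentage points higher from compound 1 to compound 2 (beyond the scatter) separates them. That step swapped one ring-bearing group for another on a saturated chain carbon bound to an aromatic carbon, and it brought a carboxy group into the molecule.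

Compound 3, `CCCCCCCCN(C)C(=O)Cn1cc(Cc2cnc(=O)n(CC(=O)N3CCOCC3)c2)c(=O)nc1SCc1ccc(F)cc1`, keeps everything else and differs from compound 2 only by morpholin-4-yl in place of hydroxy on a carbonyl carbon. Cut one bond further out, the change reads carboxy to (morpholin-4-yl)carbonyl. Going by the values given here, no measured pair shows this exchange, so the one step measured does not bear on it directly; it only says that the compound carrying carboxy sits at the higher of the two numbers. With nothing pointing either way, the expected step of a number 6 percentage points lower from compound 2 to compound 3 (within the scatter) is none beyond the scatter, and the range is kept wide to reflect that. Compound 3 is therefore estimated at 50%, between 25% and 75%.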

Compound 3, a percentage reported as inhibition, at one concentration (the size of the read-out at that concentration, not a potency): 64%
Compound 3: the middle estimate sits 14 percentage points below what was measured; the measured number falls inside the stated range.
By their numbers in this assay, from the lowest: compound 1; then compounds 2 and 3 (each within the scatter of the next).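

In this assay, for the compounds shown here, the step of a number 8 percentage points higher from compound 2 to compound 3 (within the scatter) is the first look at a change made on the carbonyl carbon itself, with the rest of the molecule held constant. Replacing hydroxy with morpholin-4-yl turns the carboxy group into (morpholin-4-yl)carbonyl, removing the hydrogen-bond donor and adding a six-membered non-aromatic ring, yet the two readings stay within the scatter of each other, so a free carboxy group is not required on this carbonyl carbon for the level of inhibition seen at this single test concentration. Nothing measured here explains why so large a change in the group leaves the reading within the scatter.

The compounds shown leave open whether the ring oxygen of morpholin-4-yl matters, which piperidin-1-yl on the same carbonyl carbon could test, and whether a small open-chain group such as dimethylamino or methoxy would give a similar reading. Going by these compounds, since each reading is the size of the effect at one concentration rather than a potency, a real difference in potency between compound 2 and compound 3 also remains open.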